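This account rests on a few compounds, and the source may have more. Where it says the series, first, only, none or still open, it means among the compounds named here.

Measured compounds:
compound 1 `CN(CCCN1CCCCC1)c1cccc(C(=O)N2CCc3ccc(OS(N)(=O)=O)cc3C2)c1` with 30.6% in an assay on HEK293 cells for inhibition of Steryl-sulfatase (Homo sapiens), tested at 1 uM; a lower number here means a weaker effect, a higher number a stronger effect of the compound at the concentration tested;
compound 2 `NS(=O)(=O)Oc1ccc2c(c1)CN(C(=O)c1cccc(N3CCc4ccccc4C3)c1)CC2` with 50.2%.

Among the compounds with values here, compound 2 holds the higher of the two numbers in this assay; the only comparison available is a number 19.6 percentage points higher from compound 1 to compound 2 (beyond the scatter), a modest gain when the cyclic amine replaced the open-chain one.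

Compound 3 `CCN(Cc1ccccn1)c1cccc(C(=O)N2CCc3ccc(OS(N)(=O)=O)cc3C2)c1` differs from compound 2 by ethyl((pyridin-2-yl)methyl)amino in place of 1,2,3,4-tetrahydroisoquinolin-2-yl on an aromatic carbon. Within the data shown here, the single measured step that bears on this change is a number 19.6 percentage points higher from compound 1 to compound 2 (beyond the scatter): there, moving from an open-chain amino substituent to the ring-closed one raised the inhibition modestly. Among the measured compounds shown here, compound 3 moves back to an open-chain amino substituent, though one that carries an aromatic ring rather than the piperidine-bearing chain of compound 1, and no measured pair shows that exact exchange. A modest fall is therefore expected rather than a large one.

Compound 3 is estimated to give 38%, in the range 20% to 56%. The step this estimate implies is expected to be a number 12.2 percentage points lower from compound 2 to compound 3 (beyond the scatter).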

Compound 3, a percentage reported as inhibition, at one concentration (the size of the read-out at that concentration, not a potency): 19.9%
Compound 3: the middle estimate sits 18.1 percentage points above what was measured; measured number below the stated range.
By their numbers in this assay, from the lowest: compound 3; then compound 1; then compound 2.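

Exchanging 1,2,3,4-tetrahydroisoquinolin-2-yl for ethyl((pyridin-2-yl)methyl)amino gave a number 30.3 percentage points lower from compound 2 to compound 3 (beyond the scatter) in this assay, although each group has 10 heavy atoms, so the read-out at this position separates groups of equal heavy-atom count. The open-chain groups also differ from each other: ethyl((pyridin-2-yl)methyl)amino in place of methyl(3-(piperidin-1-yl)propyl)amino gave a number 10.7 percentage points lower from compound 1 to compound 3 (beyond the scatter). Of the three substituents, the ring-closed 1,2,3,4-tetrahydroisoquinolin-2-yl therefore gives the highest number, with both open-chain groups beneath it. No measurement here accounts for these differences.

The compounds leave open whether the closed ring or the carbon-only aromatic ring of the 1,2,3,4-tetrahydroisoquinolin-2-yl group goes with the higher number. A morpholine ring or a benzyl(ethyl)amino group at this position would bear on that question.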